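A few compounds are considered here, and "the series" means these few. Any claim that something is new, unique, unknown or untested is made for them only; others in the source may bear on it.

Going by the values given here, in an ADME assay on microsomes from liver (Homo sapiens) for metabolic stability (a lower number here means slower removal, a higher number faster removal of the compound), compound 2 `CC(=O)N[C@@H]1CC[C@H](C(=O)Nc2cc(-c3cnn4c3CC(C)(C)C4)c(Cl)cn2)C1` gives 38 mL.min-1.g-1, the only actual number so far. Compound 1 `CC(=O)N[C@@H]1CCC[C@H](C(=O)Nc2cc(-c3cnn4c3CC(C)(C)C4)ccn2)C1` gives < 3 mL.min-1.g-1, which is a limit of the assay and not a number. Among the compounds with values here, no measured pair yet isolates a single structural change. Compound 3 `CC1(C)Cc2c(-c3cc(NC(=O)[C@H]4C[C@@H](O)C4)ncc3Cl)cnn2C1` differs from compound 2 in one group: 3-hydroxycyclobutyl in place of 3-acetamidocyclopentyl on a carbonyl carbon. A moderate fall in this assay is expected, an estimated step of a 2.5-fold lower number from compound 2 to compound 3 (0.40 log units; beyond the scatter). For compound 3 the estimate is 15 mL.min-1.g-1, with an expected range from 5 mL.min-1.g-1 to 40 mL.min-1.g-1.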

Compound 3, intrinsic clearance in microsomes in the Homo sapiens assay: 25 mL.min-1.g-1
Compound 3: middle estimate off by 1.7-fold (0.22 log units), on the low side, within the range that was stated.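

Going by these compounds alone, replacing 3-acetamidocyclopentyl with 3-hydroxycyclobutyl on a carbonyl carbon is the first single change that can be read in the Homo sapiens assay, where compound 2 gives 38 mL.min-1.g-1 and compound 3 gives 25 mL.min-1.g-1 and the change gives a 1.5-fold lower number from compound 2 to compound 3 (0.18 log units; within the scatter) so the two compounds cannot be told apart there. In a physicochemical assay for lipophilicity, using the shake flask method, measured as octanol-water partition, at pH 7.4 (a lower number here means a more polar compound, a higher number a more lipophilic compound), compound 2 gives 3.5 and compound 3 gives 3.2 and the same change gives a number 0.30 log units lower from compound 2 to compound 3 (within the scatter) so this position takes the smaller group without a step beyond the scatter in either assay. Going by these compounds, whether an amine or a carboxylic acid on this ring would behave alike remains open. Nothing shown gives a cause for this result.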